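Swapping an Amide for a Sulfonamide on a Dopamine Ligand

The compounds below may be only part of what the source reports. "The series", "measured", "known", "first", "only" and "open" are said of these compounds alone.

Among the measured compounds shown here, compound 1 `CCCN(CC[C@H]1CC[C@H](NC(=O)/C=C/c2ccc(F)cc2)CC1)[C@H]1CCc2nc(N)sc2C1` was tested in an assay on brain for displacement of a labelled ligand from D(3) dopamine receptor (Rattus norvegicus) (a lower number here means a stronger inhibitor, a higher number a weaker inhibitor), where compound 1 gives 1 nM, the lowest of the two numbers measured so far. Its nearest neighbour is compound 2 `CCCN(CC[C@H]1CC[C@H](NC(=O)c2cccc3ncccc23)CC1)[C@H]1CCc2nc(N)sc2C1`, which in this assay gives 1.6 nM; the step of a 1.6-fold higher number from compound 1 to compound 2 (0.20 log units; within the scatter) comes from a change of the aromatic group on the carbonyl carbon alone. Compound 3 `CCCN(CC[C@H]1CC[C@H](NS(=O)(=O)c2cccc(C)c2)CC1)[C@H]1CCc2nc(N)sc2C1` has not yet been measured. It differs from compound 1 as follows: (3-methylphenyl)sulfonyl in place of (2-(4-fluorophenyl)ethenyl)carbonyl on an amine nitrogen. For the measured compounds named here, the only measured step, a 1.6-fold higher number from compound 1 to compound 2 (0.20 log units; within the scatter), kept the carbonyl in place and varied just the aromatic part, so it does not speak directly to exchanging the carbonyl for a sulfonyl. Without a direct precedent, a moderately weaker binding is expected for compound 3, described as a 10-fold higher number from compound 1 to compound 3 (1.00 log units; beyond the scatter). Compound 3 is therefore estimated at 10 nM, within a range from 2 nM to 60 nM.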

Compound 3, inhibition constant: 0.89 nM
For compound 3 the middle estimate is 11-fold (1.05 log units) above the measured one; the whole stated range lies above it.
By their numbers in this assay, from the lowest: compounds 3, 1 and 2 (each within the scatter of the next).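

In this assay the exchange on the amine nitrogen gives a 1.1-fold lower number from compound 1 to compound 3 (0.05 log units; within the scatter) and so leaves binding unchanged within the scatter. This shows that the carbonyl is not essential in this pair: a sulfonyl bearing a different aromatic group, 3-methylphenyl, serves equally well at this position, something the earlier step could not show since it kept the carbonyl. No measurement is available to explain why binding holds across this change.

The carbonyl and the group attached to it changed together here, so the contribution of the sulfonyl alone cannot be separated from that of the 3-methylphenyl ring. Going by these compounds, it also remains open whether binding would hold with a small methyl group on the sulfonyl in place of the ring, or with a carboxylic acid on the ring.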